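Glutarimide for cyclohexyl on an imide nitrogen

The compounds below may be only part of what the source reports. "The series", "measured", "known", "first", "only" and "open" are said of these compounds alone.

The series is followed in a physicochemical assay for lipophilicity, read by HPLC, at pH 7.4; a higher number here means a more lipophilic compound, a lower number a more polar compound. Compound 1, `O=C(COCCOCCOCc1ccccc1)NCc1ccc2c(c1)C(=O)N(C1CCC(=O)NC1=O)C2=O`, has been measured: in this assay compound 1 gives 1.8. On these data alone, compound 2, `O=C1c2cccc(OCCOCCOCCOCc3ccccc3)c2C(=O)N1C1CCCCC1`, stands without a number in this assay, where compound 2 is entered as "not determined" (no result reported), so its place on the scale is unknown. Compound 3, `O=C1CCC(N2C(=O)c3cccc(OCCOCCOCCOCc4ccccc4)c3C2=O)C(=O)N1`, is the partner of compound 2 and is yet to be measured. The change from compound 2 to compound 3 is 2,6-dioxopiperidin-3-yl in place of cyclohexyl on an amide-type nitrogen in a ring. Nothing about this pair has been measured, so the size of the step rests on expectation alone: the account expects compound 3 to come out lower than compound 2 in this assay, toward the polar side, by a step beyond the usual scatter. Compound 3 is estimated at 2 in this assay, with a range from 1.4 to 2.6.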

Compound 3, distribution coefficient: 2.6
The estimate for compound 3 lay 0.60 log units below the measured number; low and high end bracket the measured number.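

In this assay, within the data shown here, compound 3 gives 2.6 but compound 2 has no number to set against it, so no step between compound 2 and compound 3 can be read. On these data alone, how far 2,6-dioxopiperidin-3-yl in place of cyclohexyl moves this assay stays open. No evidence at hand bears on this result.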